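Acetylpyrrolidinyl amide in the aryl sulfonamide series

The source may hold more compounds than are shown below. What is called first, only, known or untested is meant among the compounds shown, and "the series" means these compounds.

Compound 1 `O=C(Cn1ccnc1)N1CCC(NS(=O)(=O)c2cc(S(=O)(=O)c3ccccc3)ccc2C(F)(F)F)CC1` gives the highest of the three numbers in a functional assay on U2OS cells for antagonist activity at proto-oncogene Wnt-3 (Homo sapiens), read by a luciferase reporter, with a stated time of 18 h (a lower number here means that less compound is needed, a higher number that more compound is needed for the effect), at 230 nM. Compound 2 `CC(C)(C)OC(=O)N1CCC[C@@H]1C(=O)N1CCC(NS(=O)(=O)c2cc(S(=O)(=O)c3ccccc3)ccc2C(F)(F)F)CC1` gives 210 nM in this assay, and compound 3 `CC(C)(C)OC(=O)N1C(=O)CC[C@H]1C(=O)N1CCC(NS(=O)(=O)c2cc(S(=O)(=O)c3ccccc3)ccc2C(F)(F)F)CC1` gives 90 nM in this assay; the gap from compound 1 to compound 3 lies beyond the scatter, the gap from compound 1 to compound 2 does not. Compound 4 `CC(=O)N1CCC[C@H]1C(=O)N1CCC(NS(=O)(=O)c2cc(S(=O)(=O)c3ccccc3)ccc2C(F)(F)F)CC1` carries 1-acetylpyrrolidin-2-yl in place of (1H-imidazol-1-yl)methyl on a carbonyl carbon. Among the measured compounds shown here, the one measured step that bears on this exchange is the one where 1-(tert-butoxycarbonyl)pyrrolidin-2-yl replaced (1H-imidazol-1-yl)methyl on a carbonyl carbon: a 1.1-fold lower number from compound 1 to compound 2 (0.04 log units; within the scatter). For the measured compounds named here, the acetyl group of compound 4 is not the tert-butoxycarbonyl group of compound 2, and no measured pair shows the size of that exchange on its own. The expected change in this assay is therefore a 1.2-fold lower number from compound 1 to compound 4 (0.06 log units; within the scatter), not beyond the scatter. The estimate for compound 4 in this assay is 200 nM, with a range from 80 nM to 500 nM.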

Compound 4, half-maximal effective concentration: 250 nM
For compound 4 the middle estimate is 1.3-fold (0.10 log units) below the measured one; the measured number falls inside the stated range.
By their numbers in this assay, from the lowest: compound 3; then compounds 2, 1 and 4 (each within the scatter of the next).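

In this assay, 1-acetylpyrrolidin-2-yl on this carbonyl carbon gives no separation from (1H-imidazol-1-yl)methyl, with a 1.1-fold higher number from compound 1 to compound 4 (0.04 log units; within the scatter). The exchange of the two ring-bearing groups also stays unresolved, with a 1.2-fold higher number from compound 2 to compound 4 (0.08 log units; within the scatter), so these three groups cannot be told apart at this position despite the loss of the aromatic ring and the differing atom counts. No available evidence speaks to why the number stays unchanged across these groups.

Compound 2 and compound 4 are drawn with opposite configuration at the defined stereocentre, so the role of that centre remains unseparated from the change of the group on the ring nitrogen. As far as these compounds go, it also remains open whether a free amine on that ring nitrogen, or a carboxylic acid in place of the acetyl group, would move the number beyond the scatter.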